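A few compounds are considered here, and "the series" means these few. Any claim that something is new, unique, unknown or untested is made for them only; others in the source may bear on it.

Measured compounds:
- compound 1 `CN1CCN(CCCN(C[C@H]2Cc3ccccc3CN2)[C@H]2CCCc3cccnc32)CC1`: 10%
- compound 2 `c1ccc2c(c1)CN[C@@H](CN(CC1CCNCC1)[C@H]1CCCc3cccnc31)C2`: 65%
- compound 3 `c1cnc(CN(CCCN2CCNCC2)[C@H]2CCCc3cccnc32)nc1`: 68%

All three numbers come from an ADME assay on microsomes from liver (Rattus norvegicus) for metabolic stability, read by LC-MS, with a stated time of 10 min, tested at 0.5 uM; a lower number here means that less of the compound is left, a higher number that more of the compound is left. Compound 3 stands highest of the three numbers, but its gap to compound 2 lies within the scatter, so these two cannot be ranked; compound 1 lies far below both. Going by the values given here, the only step between measured compounds, a number 55 percentage points higher from compound 1 to compound 2 (beyond the scatter), changes a group at a different place from the one now in question. Compound 4 `c1cnc2c(c1)CCC[C@@H]2N(CCCN1CCNCC1)Cc1cc2ccccc2cn1` differs from compound 3 by isoquinolin-3-yl in place of pyrimidin-2-yl on a saturated chain carbon bound to an amine nitrogen. Among the compounds with values here, no measured step bears on this exchange of one aromatic group for another, so there is no basis to expect a step beyond the scatter in this assay in either direction. Compound 4 is therefore estimated at 58%, between 30% and 78%. The expected step is a number 10 percentage points lower from compound 3 to compound 4 (within the scatter).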

Compound 4, percent of the compound remaining: 59%
For compound 4 the middle estimate is 1 percentage points below the measured one, within the range that was stated.
By their numbers in this assay, from the lowest: compound 1; then compounds 4, 2 and 3 (each within the scatter of the next).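

In this assay the exchange gives a number 9 percentage points lower from compound 3 to compound 4 (within the scatter), so at this place, on a saturated chain carbon bound to an amine nitrogen, isoquinolin-3-yl and pyrimidin-2-yl cannot be told apart. A second aromatic ring can thus enter here with no readable change in how much compound is left. Nothing measured here explains this result. Open, as far as these compounds go, is whether a group of another kind at this place, such as a carboxylic acid or a simple methyl, would move the number beyond the scatter.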